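Acetyl for hydroxyl hydrogen: expected effect on cytotoxicity

The source may report more compounds than this note shows. Statements on the series, on what has been measured and on what is new or still open speak of the compounds shown alone.

Of the compounds shown here, three sharing a core have been measured in a functional assay on Col2 cells (Homo sapiens) for cytotoxicity, read by sulforhodamine B assay; a higher number here means that more compound is needed for the effect, a lower number that less compound is needed. Compound 1 `C=C1CC[C@@H]2[C@](C)(COC(C)=O)[C@H](OC(C)=O)CC[C@@]2(C)[C@@H]1C/C=C1/C(=O)OC[C@H]1OC(C)=O` gives 10.8 uM. Compound 2 `C=C1CC[C@@H]2[C@](C)(CO)[C@H](OC(C)=O)CC[C@@]2(C)[C@@H]1C/C=C1/C(=O)OC[C@H]1OC(C)=O` gives 10.2 uM in this assay. Compound 3 `C=C1CC[C@@H]2[C@](C)(CO[Si](C)(C)C(C)(C)C)[C@H](O)CC[C@@]2(C)[C@@H]1C/C=C1/C(=O)OC[C@H]1O` gives 17.1 uM in this assay; its value and those of compound 1 and compound 2 lie within the scatter of one another, so no order among the three is drawn.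

Among the compounds with values here, the one counted change among the measured compounds is acetyl in place of hydrogen on an oxygen on a saturated carbon; it made a 1.1-fold higher number from compound 2 to compound 1 (0.02 log units; within the scatter). Compound 4 `C=C1CC[C@@H]2[C@](C)(CO[Si](C)(C)C(C)(C)C)[C@H](OC(C)=O)CC[C@@]2(C)[C@@H]1C/C=C1/C(=O)OC[C@H]1O` has not yet been measured in this assay. It differs from compound 3 by acetyl in place of hydrogen on an oxygen on a saturated carbon. The difference between the cores of compound 2 and compound 3 is not broken down here. The place lines of the two changes are not identical: from compound 2 to compound 1 the oxygen sits on a saturated carbon whose other neighbour is a saturated chain carbon, whereas from compound 3 to compound 4 the other neighbour is a saturated ring carbon, so this is the same kind of change rather than the same change.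

Within the data shown here, the step from compound 3 to compound 4 in this assay is expected to be a 1.0-fold lower number from compound 3 to compound 4 (0.00 log units; within the scatter), which rests on the single precedent a 1.1-fold higher number from compound 2 to compound 1 (0.02 log units; within the scatter) and on nothing more. Compound 4 is therefore estimated at 17 uM, with an expected range from 8 uM to 35 uM.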

Compound 4, concentration for half-maximal effect: 11.3 uM
For compound 4 the middle estimate is 1.5-fold (0.18 log units) above the measured one; measured number inside the range.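

In this assay the new step is a 1.5-fold lower number from compound 3 to compound 4 (0.18 log units; within the scatter), so hydroxy to acetoxy at this place gives no readable shift. Set beside the earlier step, the same kind of change reads alike on the two cores: the same change on two cores in this assay, a 1.1-fold higher number (0.02 log units; within the scatter) from compound 2 to compound 1 and a 1.5-fold lower number (0.18 log units; within the scatter) from compound 3 to compound 4, 1.6-fold (0.20 log units) apart, within the scatter of two such steps. Within the data shown here, this supports carrying acetyl in place of hydrogen on an oxygen on a saturated carbon between these two cores as a change with no readable effect in this assay, but it rests on only two pairs, with the oxygen on a saturated carbon whose other neighbour is a saturated chain carbon in one pair and a saturated ring carbon in the other, and it shows neither that the result holds on other cores nor that the two places are interchangeable.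

Open, from the compounds shown here alone, is whether a group other than acetyl on such an oxygen, for instance a longer acyl chain, a carbamate or an ester bearing an amine, would give a step beyond the scatter. Also open is what the silyl ether on the core of compound 3 contributes, as no single-place step among the compounds shown isolates it from a free hydroxyl or an acetoxy group on that oxygen.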